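Chlorine in Place of Fluorine on the Benzyl Group

The source may report more compounds than this note shows. Statements on the series, on what has been measured and on what is new or still open speak of the compounds shown alone.

Compound 3 `CC(C(=O)NCc1ccc(C(F)(F)F)nc1N(Cc1ccc(F)cc1)S(=O)(=O)c1ccc(F)cc1)c1ccc(NS(C)(=O)=O)c(F)c1` gives 2.99 nM in an assay on CHO cells for antagonist activity at transient receptor potential cation channel subfamily V member 1 (Homo sapiens), read by scintillation counting, with a stated time of 5 min (on this read-out lower numbers stand for stronger inhibition and higher numbers for weaker inhibition), the lowest number among the three measured compounds. Compound 2 `CC(C(=O)NCc1ccc(C(F)(F)F)nc1N(Cc1ccccc1)S(=O)(=O)c1ccc(F)cc1)c1ccc(NS(C)(=O)=O)c(F)c1` gives 3.87 nM in this assay, and compound 1 `CC(C(=O)NCc1ccc(C(F)(F)F)nc1N(C)S(=O)(=O)c1ccccc1)c1ccc(NS(C)(=O)=O)c(F)c1` gives 100 nM. Compound 4 `CC(C(=O)NCc1ccc(C(F)(F)F)nc1N(Cc1ccc(Cl)cc1)S(=O)(=O)c1ccc(F)cc1)c1ccc(NS(C)(=O)=O)c(F)c1` differs from compound 3 in one place: chloro in place of fluoro on an aromatic carbon. Going by the values given here, the only measured step at this aromatic carbon is a 1.3-fold lower number from compound 2 to compound 3 (0.11 log units; within the scatter), where fluoro replaced hydrogen. Among the compounds with values here, no measured step swaps fluoro for chloro, so the evidence is indirect, but that small step suggests a change here need not move the number much, and no step beyond the scatter is expected. Compound 4 is therefore estimated to give 2.7 nM, with a likely range from 1 nM to 7.5 nM, which means an expected step of a 1.1-fold lower number from compound 3 to compound 4 (0.04 log units; within the scatter).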

Compound 4, inhibition constant: 6 nM
Beside the measured number, compound 4's estimate is 2.2-fold (0.35 log units) below it; the measured number falls inside the stated range.
By their numbers in this assay, from the lowest: compounds 3, 2 and 4 (each within the scatter of the next); then compound 1.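

With chloro on this aromatic carbon, the benzyl group has now been read with hydrogen, fluoro and chloro in this assay. Chloro in place of fluoro gives a 2.0-fold higher number from compound 3 to compound 4 (0.30 log units; within the scatter) and stays level with the fluoro compound, with a 1.6-fold higher number from compound 2 to compound 4 (0.19 log units; within the scatter) for chloro in place of hydrogen, so among compounds 2, 3 and 4 this place accepts a heavier halogen without a step beyond the scatter. Nothing available explains this result. Left open is whether a methoxy group, an amine or a carboxylic acid on this same aromatic carbon would also stay within the scatter.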